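The source may report more compounds than this note shows. Statements on the series, on what has been measured and on what is new or still open speak of the compounds shown alone.

Of the compounds shown here, two bearing the same core have so far been tested in a functional assay on A549 cells (Homo sapiens) for antiproliferative activity, tested at 1 uM; a higher number here means more inhibition at the concentration tested (going by the name of the read-out), a lower number less inhibition. Compound 1 `Cc1nn(-c2ccccc2)c(Oc2ccc(Cl)cc2)c1/C=N/OCc1ccc(C(=O)OC(C)(C)C)cc1` gives -6.5% in this assay, the lower of the two numbers. Compound 2 `Cc1nn(C)c(Oc2ccccc2)c1/C=N/OCc1ccc([N+](=O)[O-])cc1` gives 39.4% in this assay, a value that lies beyond the usual scatter above that of compound 1; the two compounds differ in several places at once, so the gap cannot be tied to a single change.

Compound 3 `CCOC(=O)c1ccc(CO/N=C/c2c(C)nn(-c3ccccc3)c2Oc2ccc(Cl)cc2)cc1` has not yet been measured. It differs from compound 1 in one place: ethyl in place of tert-butyl on an oxygen next to a carbonyl group. An ester with a shorter alkyl group on its oxygen takes the place of the larger one. For the measured compounds named here, no pair of measured compounds shows what such a change does in this assay, so the step is expected to be small, in no clear direction, within the scatter: a number 9.5 percentage points higher from compound 1 to compound 3 (within the scatter). Compound 3 is accordingly expected to give about 3% in this assay, somewhere between -15% and 25%.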

Compound 3, a percentage reported as inhibition, at one concentration (the size of the read-out at that concentration, not a potency): -9.9%
For compound 3 the middle estimate is 12.9 percentage points above the measured one; the range from low to high includes it.
By their numbers in this assay, from the lowest: compounds 3 and 1 (each within the scatter of the next); then compound 2.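

For the compounds shown here, the tert-butyl to ethyl swap on an oxygen next to a carbonyl group gives the first comparison in this assay between compounds that differ in only one place: a number 3.4 percentage points lower from compound 1 to compound 3 (within the scatter). Between these two groups, then, the size of the alkyl group on this ester oxygen makes no difference that can be told apart from the usual scatter of this assay, and the swap does not separate compound 3 from compound 1. No outside measurement is available to explain this result.

From the compounds shown here alone, whether a carboxylic acid, an amide or a longer chain at this place would give a different number stays open. Also open, going by these compounds, is what the ester contributes compared with the nitro group of compound 2, which differs from compound 1 in several places at once.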